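The source may report more compounds than this note shows. Statements on the series, on what has been measured and on what is new or still open speak of the compounds shown alone.

Measured compounds:
Compound 1 `NC(=O)c1ncn(CCC2(O)NC(=O)C(OCc3ccccc3)=C2OCc2ccccc2)n1`: > 100000 nM
Compound 2 `COC(=O)c1ncn(C[C@H](O)[C@H]2OC(=O)C(OCc3ccccc3)=C2OCc2ccccc2)n1`: > 100000 nM

In a functional assay on SW-620 cells (Homo sapiens) for antiproliferative activity, read by MTT assay, with a stated time of 72 h (on this read-out higher numbers stand for weaker inhibition and lower numbers for stronger inhibition), compound 1 gives only a limit, > 100000 nM. Compound 2 likewise returns only a limit in this assay, > 100000 nM. Both values therefore sit at the limit of > 100000 nM in this assay, at which 2 of the 2 values shown sit, so compound 1 stands at the ceiling of what this assay reports, with no number to place it above or below compound 2. Compound 3 `NC(=O)c1ncn(CCC2(O)NC(=O)C(OCc3ccccc3)=C2OCc2ccccc2)c1C(N)=O` differs from compound 1 by 4,5-dicarbamoyl-1H-imidazol-1-yl in place of 3-carbamoyl-1H-1,2,4-triazol-1-yl on a saturated chain carbon, two bonds along the chain from a saturated ring carbon. Among the measured compounds shown here, no measured step connects two compounds here, so the size of the expected change rests on the structures alone; compound 3 is expected to remain near the limit, with a step that the limit leaves unreadable from compound 1 to compound 3 adding nothing beyond the scatter. Compound 3 is estimated at 150000 nM, between 50000 nM and 500000 nM.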

Compound 3, half-maximal inhibitory concentration: > 100000 nM
Compound 3: a limit, no number; the forecaster's own chance of this, stated with the estimate: 85%; the middle value is on the limit's open side.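

Compound 3 gives only a limit, > 100000 nM, so no step can be read from compound 1 to compound 3. The compounds shown leave open whether any change to the shared core yields a readable number in this assay.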